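Swapping the Furan Ring for an Aminophenyl Group

A few compounds are considered here, and "the series" means these few. Any claim that something is new, unique, unknown or untested is made for them only; others in the source may bear on it.

Three compounds share one core, seen in compound 1 `O=C(/C=C/c1ccc2c(c1)B(O)OC2)c1ccccc1`. In a functional assay on MDA-MB-231 cells (Homo sapiens) for cytotoxicity, read by MTT assay, with a stated time of 48 h (a lower number here means a stronger inhibitor, a higher number a weaker inhibitor), compound 1 gives 2300 nM. Compound 2 `O=C(/C=C/c1ccc2c(c1)B(O)OC2)c1ccco1` gives 7300 nM, the highest number of the three, and compound 3 `Cc1cccc(C(=O)/C=C/c2ccc3c(c2)B(O)OC3)c1` gives 4500 nM. The step of a 3.2-fold higher number from compound 1 to compound 2 (0.50 log units; beyond the scatter) is the only one beyond the scatter; a 1.6-fold lower number from compound 2 to compound 3 (0.21 log units; within the scatter) and a 2.0-fold higher number from compound 1 to compound 3 (0.29 log units; within the scatter) both lie within it.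

Compound 4 `Nc1cccc(C(=O)/C=C/c2ccc3c(c2)B(O)OC3)c1` differs from compound 2 by 3-aminophenyl in place of furan-2-yl on a carbonyl carbon. Within the data shown here, two measured steps bear on this: a 3.2-fold higher number from compound 1 to compound 2 (0.50 log units; beyond the scatter), where the entering furan ring raised the number, and a 1.6-fold lower number from compound 2 to compound 3 (0.21 log units; within the scatter), where a substituted phenyl in place of the furan gave a number within the scatter of compound 2. Both suggest that a six-membered ring of carbon in place of the furan brings the number back toward those of compound 1 and compound 3. Among the measured compounds shown here, no measured step involves an amino group, so the expected step of a 2.1-fold lower number from compound 2 to compound 4 (0.32 log units; beyond the scatter) is taken as modest and downward. Compound 4 is therefore expected to give 3500 nM, within 1500 nM to 8000 nM.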

Compound 4, half-maximal inhibitory concentration: 3200 nM
The estimate for compound 4 lay 1.1-fold (0.04 log units) above the measured number, within the range that was stated.
By their numbers in this assay, from the lowest: compounds 1, 4, 3 and 2 (each within the scatter of the next, the first and the last beyond it).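

In this assay, 3-aminophenyl in place of furan-2-yl gives a 2.3-fold lower number from compound 2 to compound 4 (0.36 log units; beyond the scatter), so compound 4 joins compound 1 in standing beyond the scatter of compound 2, whereas the 3-methylphenyl of compound 3 does not. On the phenyl ring itself the amino group leaves no readable mark, for both a 1.4-fold lower number from compound 3 to compound 4 (0.15 log units; within the scatter) and a 1.4-fold higher number from compound 1 to compound 4 (0.14 log units; within the scatter) lie within the scatter, even though the entering group carries a hydrogen-bond donor that furan-2-yl lacks. Nothing shown here accounts for these steps.

The compounds shown leave open whether a carboxylic acid or a dimethylamino group in place of the amino group would move the number beyond the scatter of compound 1. They also leave open whether any group on this carbonyl carbon can bring the number clearly below that of compound 1.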